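This account rests on a few compounds, and the source may have more. Where it says the series, first, only, none or still open, it means among the compounds named here.

Measured compounds:
compound 1, `CO[C@@H]1C[C@@H]2[C@H]([C@]1(N)C(=O)O)[C@@]2(F)C(=O)O`: 39.2 nM
compound 2, `N[C@]1(C(=O)O)[C@H]2[C@@H](C[C@H]1OCc1cccc([N+](=O)[O-])c1)[C@]2(F)C(=O)O`: 7.87 nM

Both numbers come from an assay on CHO cells for binding affinity to metabotropic glutamate receptor 2 (Rattus norvegicus); on this read-out lower numbers stand for stronger inhibition and higher numbers for weaker inhibition. Compound 2 holds the lower of the two values; compound 1 sits at a higher number, and the gap between them lies beyond the usual scatter, so on this pair compound 2 is the stronger binder. The two compounds share the same bicyclic amino-acid core; compound 1 carries a methoxy group, compound 2 the larger benzyl ether bearing a nitro group. Going by the values given here, no single-change pair between measured compounds is available, so the effect of a substituent change on the aromatic ring of that ether has not been observed directly.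

Compound 3, `Nc1cccc(CO[C@@H]2C[C@@H]3[C@H]([C@]2(N)C(=O)O)[C@@]3(F)C(=O)O)c1`, is the next case. It differs from compound 2 as follows: amino in place of nitro on an aromatic carbon. The ether itself and the rest of the core are unchanged.

Among the compounds with values here, with no measured step on this ring to lean on, the expectation for compound 3 is a step of a 1.4-fold higher number from compound 2 to compound 3 (0.15 log units; within the scatter), that is no change beyond the scatter, perhaps a slightly higher number. In this assay compound 3 is therefore estimated at 11 nM, with a range from 3.5 nM to 35 nM.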

Compound 3, inhibition constant: 15.4 nM
Estimate against measurement, compound 3: 1.4-fold (0.15 log units) below; low and high end bracket the measured number.
By their numbers in this assay, from the lowest: compounds 2 and 3 (each within the scatter of the next); then compound 1.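

In this assay, amino in place of nitro on an aromatic carbon, meta to a large group, gives a 2.0-fold higher number from compound 2 to compound 3 (0.29 log units; within the scatter), so on this pair binding does not depend on the nitro group, and this ring place accepts either group. The aromatic part of the ether also has its first single-change reading: 3-aminophenyl in place of hydrogen on a saturated chain carbon bound to an oxygen on a saturated carbon gives a 2.5-fold lower number from compound 1 to compound 3 (0.41 log units; beyond the scatter), a modest step that sets compound 3 apart from the methoxy ether of compound 1. Nothing available here accounts for the size of either step.

The compounds shown leave open whether other groups at this ring place, such as a hydroxyl or a carboxylic acid, would also give numbers close to those of compound 2 and compound 3, and whether moving the amino group to another ring carbon would change the number. Also open, as far as these compounds go, is whether a longer chain linking the ring to the ether oxygen would keep the step seen from the methoxy ether.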